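The source may hold more compounds than are shown below. What is called first, only, known or untested is meant among the compounds shown, and "the series" means these compounds.

Working notes on the hydroxamate ester series.

Of the compounds shown here, two carry numbers so far. In a functional assay on PC-3 cells (Homo sapiens) for inhibition, read by sulforhodamine B assay, with a stated time of 48 h (on this read-out higher numbers stand for weaker inhibition and lower numbers for stronger inhibition), compound 1 `CC[C@H](C)C(=O)O[C@H]1C[C@@H](C)C=C2C=C[C@H](C)[C@H](CC[C@@H](O)C[C@@H](CC(=O)NO)OC(C)=O)[C@H]21` gives 11400 nM. In this assay compound 2 `CC[C@H](C)C(=O)O[C@H]1C[C@@H](C)C=C2C=C[C@H](C)[C@H](CC[C@@H](O)C[C@@H](CC(=O)NO)OC(=O)C(C)(C)C)[C@H]21` gives 7200 nM. Among the compounds with values here, the one step between them, a 1.6-fold lower number from compound 1 to compound 2 (0.20 log units; within the scatter), changes only the acyl group on the oxygen next to the carbonyl. Compound 2 therefore stands alongside compound 1; the gap between the two is within the scatter, so neither can be called the more potent.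

Compound 3 `CC[C@H](C)C(=O)O[C@H]1C[C@@H](C)C=C2C=C[C@H](C)[C@H](CC[C@@H](O)C[C@@H](CC(=O)NO)OC(=O)c3ccccc3)[C@H]21` is the next member and carries the change (phenyl in place of tert-butyl on a carbonyl carbon). Within the data shown here, the only measured step that bears on this position is the one from compound 1 to compound 2, and it stayed within the scatter. Among the measured compounds shown here, no measured step covers an aromatic ring entering at this carbonyl carbon, so nothing in the data points in either direction. On this basis the step from compound 2 to compound 3 in this assay is expected to be small, a 1.1-fold lower number from compound 2 to compound 3 (0.04 log units; within the scatter), with no change beyond the scatter. For compound 3 the estimate in this assay is 6500 nM, with a range from 2500 nM to 16000 nM.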

Compound 3, half-maximal inhibitory concentration: 3300 nM
Beside the measured number, compound 3's estimate is 2.0-fold (0.29 log units) above it; the measured number falls inside the stated range.
By their numbers in this assay, from the lowest: compound 3; then compounds 2 and 1 (each within the scatter of the next).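

In this assay this position proves responsive to the group on the carbonyl carbon: phenyl in place of tert-butyl gives a 2.2-fold lower number from compound 2 to compound 3 (0.34 log units; beyond the scatter) and phenyl in place of methyl gives a 3.5-fold lower number from compound 1 to compound 3 (0.54 log units; beyond the scatter), whereas the earlier change from methyl to tert-butyl gave only a 1.6-fold lower number from compound 1 to compound 2 (0.20 log units; within the scatter). Among the three groups shown, phenyl, the only one that brings a six-membered aromatic ring, is set apart from both others by modest steps beyond the scatter, while methyl and tert-butyl remain unseparated from each other. Nothing available on the series explains this difference.

Going by these compounds, it remains open whether the lower number goes with an aromatic ring at this carbonyl carbon in general or with phenyl alone, which a pyridine ring, a saturated cyclohexyl ring or a benzoyl ring carrying a chlorine or a methoxy group could help to decide. Also open, on these data alone, is how this position responds to an acyl group with a longer chain or one bearing an amine.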